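Working notes on compounds 1 to 4

This account rests on a few compounds, and the source may have more. Where it says the series, first, only, none or still open, it means among the compounds named here.

Compound 1 `O=C(CSc1nnc(-c2ccncc2)o1)c1ccccc1` is the reference point of the set. In a functional assay on MCF7 cells (Homo sapiens) for cytotoxicity, read by MTT assay and propidium iodide staining, with a stated time of 24 h (on this read-out higher numbers stand for weaker inhibition and lower numbers for stronger inhibition), compound 1 gives 370 nM. Compound 2 `O=C(CSc1nnc(-c2ccccc2F)o1)c1ccccc1` differs from compound 1 by 2-fluorophenyl in place of pyridin-4-yl on an aromatic carbon. In this assay compound 2 gives 260 nM, and the step is a 1.4-fold lower number from compound 1 to compound 2 (0.15 log units; within the scatter). Compound 3 `O=C(CSc1nnc(-c2ccncc2)o1)c1ccc(Br)cc1` differs from compound 1 by bromo in place of hydrogen on an aromatic carbon. In this assay compound 3 gives 4230 nM, a step of an 11-fold higher number from compound 1 to compound 3 (1.06 log units; beyond the scatter). Compound 3 therefore stands with the highest number of the three measured compounds.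

Compound 4 `O=C(CSc1nnc(-c2ccccc2F)o1)c1ccc(Br)cc1` has not yet been measured. It differs from compound 3 by 2-fluorophenyl in place of pyridin-4-yl on an aromatic carbon. Among the measured compounds shown here, this is the same change as the one from compound 1 to compound 2: what leaves, what enters and the place are described in the same words for both pairs. The two cores differ by bromo in place of hydrogen on an aromatic carbon, which, cut one bond further out, reads phenyl to 4-bromophenyl.

On the core of compound 1 this change made a step of a 1.4-fold lower number from compound 1 to compound 2 (0.15 log units; within the scatter), which lies within the scatter. For the measured compounds named here, only this one earlier example exists, and it sits on a core without the bromo group, so the expectation rests on that single step alone. For compound 4 the expected step is a 1.4-fold lower number from compound 3 to compound 4 (0.15 log units; within the scatter), a small move in the same direction as the earlier one. Compound 4 is thus estimated to give 3000 nM in this assay, with a range from 1500 nM to 6500 nM that allows for the change having been seen only once.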

Compound 4, half-maximal inhibitory concentration: 240 nM
Compound 4: middle estimate off by 13-fold (1.10 log units), on the high side; the whole stated range lies above it.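

In this assay the exchange of pyridin-4-yl for 2-fluorophenyl does not carry from the core of compound 1 to the core with the bromo group, where it gives an 18-fold lower number from compound 3 to compound 4 (1.25 log units; beyond the scatter), so the earlier step is a poor guide to the size of this one: the same change on two cores in this assay, a 1.4-fold lower number (0.15 log units; within the scatter) from compound 1 to compound 2 and an 18-fold lower number (1.25 log units; beyond the scatter) from compound 3 to compound 4, 12-fold (1.09 log units) apart, beyond the scatter of two such steps

The bromo group does not carry over either, giving a 1.1-fold lower number from compound 2 to compound 4 (0.03 log units; within the scatter) on the 2-fluorophenyl compounds, far from its step on the pyridin-4-yl compounds: the same change on two cores in this assay, an 11-fold higher number (1.06 log units; beyond the scatter) from compound 1 to compound 3 and a 1.1-fold lower number (0.03 log units; within the scatter) from compound 2 to compound 4, 12-fold (1.09 log units) apart, beyond the scatter of two such steps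

This shows that in these four compounds the two changes do not add up as independent steps, but it does not show what lies behind this, whether the same holds for other groups, or how far the result depends on compound 3, through which both gaps run.

From the compounds shown here alone, it remains open whether chloro or methoxy in place of the bromo group would follow the same course as bromo, and whether the effect of the bromo group would also vanish with other rings in place of 2-fluorophenyl. Equally open, going by these compounds, is how an amine or a carboxylic acid on either outer ring would behave on these two cores.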